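Replacing Cyano with Chloro in a Small Series

This account rests on a few compounds, and the source may have more. Where it says the series, first, only, none or still open, it means among the compounds named here.

In a functional assay on the whole organism for inhibition, with Rattus norvegicus as the target, with a stated time of 1 h (on this read-out higher numbers stand for an effect only at larger amounts of compound and lower numbers for an effect already at smaller amounts), three compounds sharing one core have been measured: compound 1 `CC1(C)OC(/C=C/c2ccsc2)=CC1=O` (4 mg/kg), compound 2 `CC1(C)OC(/C=C/c2cccnc2)=CC1=O` (9 mg/kg) and compound 3 `CC1(C)OC(/C=C/c2ccc(C#N)cc2)=CC1=O` (12 mg/kg). Compound 3 cannot be told apart from compound 2, since their gap lies within the usual scatter. Its number does sit clearly above that of compound 1, so a smaller dose was enough for compound 1.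

Compound 4 `CC1(C)OC(/C=C/c2ccc(Cl)cc2)=CC1=O` keeps the core and carries chloro in place of cyano on an aromatic carbon, para to a large group (chloro in place of cyano on an aromatic carbon). Going by the values given here, no measured pair shows this exchange or any other single change, so the data give no direct guide to its size. The three measured numbers do lie fairly close together, and nothing here points to a large jump. The expected change is a 1.5-fold lower number from compound 3 to compound 4 (0.18 log units; within the scatter) and would stay within the scatter, with no firm direction. For compound 4 the estimate is 8 mg/kg with an expected range from 3.5 mg/kg to 20 mg/kg until the measurement arrives.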

Compound 4, dose for half-maximal effect: 10.3 mg/kg
Estimate against measurement, compound 4: 1.3-fold (0.11 log units) below, and the stated range covers the measured number.
By their numbers in this assay, from the lowest: compound 1; then compounds 2, 4 and 3 (each within the scatter of the next).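

Going by these compounds alone, the first single-place comparison shows, in this assay, a 1.2-fold lower number from compound 3 to compound 4 (0.07 log units; within the scatter), so these two compounds cannot be told apart. Cyano leaves with its triple bond and hydrogen-bond acceptor, and the single atom of chloro enters without either, so for this pair neither feature is needed at this aromatic carbon to reach a dose in this range. Nothing measured here explains why the two groups give such similar numbers.

On these data alone, whether other groups fit at this carbon remains open, since an amine, a carboxylic acid or a methoxy group could give a very different number. Plain hydrogen at the same place would show whether cyano or chloro contributes anything at all.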